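The compounds below may be only part of what the source reports. "The series", "measured", "known", "first", "only" and "open" are said of these compounds alone.

Measured in a functional assay on the whole organism with Canis familiaris (Canis lupus familiaris) as the target, at a dose of 8 mg/kg by the oral route; a lower number here means a weaker effect, a higher number a stronger effect of the compound at the dose given:
compound 1 `Cc1nc2c(OCc3ccccc3)cccn2c1N`: 96%
compound 2 `CCc1nc2c(OCc3ccccc3)cccn2c1N`: 59%
compound 3 `CC(C)c1nc2c(OCc3ccccc3)cccn2c1N`: 0%

Compound 1 stands highest of the three numbers; both steps away from it are large and beyond the scatter: a number 37 percentage points lower from compound 1 to compound 2 (beyond the scatter), a number 96 percentage points lower from compound 1 to compound 3 (beyond the scatter). The third step, a number 59 percentage points lower from compound 2 to compound 3 (beyond the scatter), runs the same way.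

Compound 4 `Cc1nc2c(OCc3ccc(F)cc3)cccn2c1N` differs from compound 1 in one place: fluoro in place of hydrogen on an aromatic carbon. All three measured steps concern the substituent on the aromatic carbon of the core, where compound 1 carries a methyl, not the six-membered aromatic ring of carbon only. For the measured compounds named here, no measured step therefore bears on this change, and the expectation rests on compound 1 alone, already near the top of the percentage scale.

Compound 4 is expected to give 88%, with a range of 60% to 100%. The expected step, a number 8 percentage points lower from compound 1 to compound 4 (within the scatter), lies within the scatter.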

Compound 4, a percentage reported as inhibition, in the whole organism at one dose (the size of the read-out at that dose, not a potency): 93%
The estimate for compound 4 lay 5 percentage points below the measured number; low and high end bracket the measured number.
By their numbers in this assay, from the lowest: compound 3; then compound 2; then compounds 4 and 1 (each within the scatter of the next).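

In this assay, fluoro in place of hydrogen on the six-membered aromatic ring of carbon only, para to a large group, gives a number 3 percentage points lower from compound 1 to compound 4 (within the scatter) and is the first change shown on that ring. Unlike the larger alkyl groups on the core of compound 1, this change leaves the read-out within the scatter, though compound 1 at 96% leaves little room on the scale for any gain. No measured evidence bears on why this substitution is tolerated.

Still open, as far as these compounds go, is how chloro, methoxy or a carboxylic acid would behave at this place. Also open, from the compounds shown here alone, is whether fluoro elsewhere on this ring, or on the ethyl analogue, compound 2, would give the same outcome.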